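Urea series: aryl swap at the amide nitrogen

The source may hold more compounds than are shown below. What is called first, only, known or untested is meant among the compounds shown, and "the series" means these compounds.

In an assay on microsomes from intestine for inhibition of acyl-CoA:cholesterol acyltransferase (Oryctolagus cuniculus) (on this read-out higher numbers stand for weaker inhibition and lower numbers for stronger inhibition), compound 1 `CC(C)c1cccc(C(C)C)c1NC(=O)NC(c1ccccc1)c1ccccc1` gives 45 nM. Within the data shown here, compound 2 `COc1cccc(NC(=O)NCC2(c3ccccc3)CCCCC2)c1` gives in this assay 2500 nM, the highest of the two numbers measured so far; the gap to compound 1 lies beyond the scatter, but the two structures differ in more than one place, so no single step can be read from that pair. Compound 3 `Cc1ccc(NC(=O)NCC2(c3ccccc3)CCCCC2)cc1` has not yet been measured in this assay. Against compound 2 the change is 4-methylphenyl in place of 3-methoxyphenyl on an amide-type nitrogen. Among the measured compounds shown here, no measured pair carries this change or one resembling it, so there is nothing in the numbers from which to size the step; the only anchor is the value of compound 2, 2500 nM. The estimated step of no change at the digits printed from compound 2 to compound 3 (within the scatter) is therefore set at none beyond the scatter, in either direction. For compound 3 the expected value in this assay is 2500 nM, with a range from 800 nM to 8000 nM, the width reflecting the absence of any comparable step in the series.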

Compound 3, half-maximal inhibitory concentration: 4500 nM
Compound 3: the middle estimate sits 1.8-fold (0.26 log units) below what was measured; measured number inside the range.
By their numbers in this assay, from the lowest: compound 1; then compounds 2 and 3 (each within the scatter of the next).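

In this assay, among these compounds, the aryl group on the amide-type nitrogen gives the first readable step: a 1.8-fold higher number from compound 2 to compound 3 (0.26 log units; within the scatter). With the rest of the structure held, 4-methylphenyl stands in for 3-methoxyphenyl and the hydrogen-bond acceptor counted on the leaving group goes with it, yet the step stays within the scatter, so this pair shows no need for that acceptor on this read-out. No measurement in hand offers an explanation for this result.

This single pair changes the substituent and its place on the phenyl ring together, so it cannot separate the two, and compound 1 differs from both compound 2 and compound 3 in more than one place, so its steps to them cannot be read. Still open, on these data alone, is whether the same tolerance holds for a carboxylic acid, a dimethylamino group or a longer alkyl chain on the phenyl ring at this nitrogen, and how much of the gap to compound 1 belongs to the aryl group at all.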